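Para-ethyl on the benzyl ring of compound 2

The source may hold more compounds than are shown below. What is called first, only, known or untested is meant among the compounds shown, and "the series" means these compounds.

Measured so far:
compound 1 `O=C(O)CCCCCCN1C(=O)CC[C@@H]1CCC(O)Cc1ccccc1`, 32.5 nM
compound 2 `O=C(O)c1ccc(CCCN2C(=O)CC[C@@H]2CCC(O)Cc2ccccc2)s1`, 1.7 nM
compound 3 `O=C(O)c1ccc(CCCN2C(=O)CC[C@@H]2CCC(O)Cc2cccc(-c3ccccc3)c2)s1`, 203 nM

In a functional assay on HEK293 cells with prostaglandin E2 receptor EP4 subtype (Rattus norvegicus) as the target, read by cAMP accumulation (a lower number here means that less compound is needed, a higher number that more compound is needed for the effect), compound 2 gives the lowest of the three numbers; compound 1 lies beyond the scatter above it, and compound 3 furthest. Compound 4 `CCc1ccc(CC(O)CC[C@H]2CCC(=O)N2CCCc2ccc(C(=O)O)s2)cc1` differs from compound 2 by ethyl in place of hydrogen on an aromatic carbon. Among the compounds with values here, the one step that bears on this is a 120-fold higher number from compound 2 to compound 3 (2.08 log units; beyond the scatter), where phenyl entered at the same aromatic carbon. Ethyl is smaller than phenyl, so a loss is expected for compound 4 but a smaller one, a 4.7-fold higher number from compound 2 to compound 4 (0.67 log units; beyond the scatter). For compound 4 the estimate in this assay is 8 nM, with a range from 2 nM to 40 nM.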

Compound 4, half-maximal effective concentration: 275 nM
The estimate for compound 4 lay 34-fold (1.54 log units) below the measured number, outside the stated range (above it).
By their numbers in this assay, from the lowest: compound 2; then compound 1; then compounds 3 and 4 (each within the scatter of the next).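

In this assay, the step of a 160-fold higher number from compound 2 to compound 4 (2.21 log units; beyond the scatter) shows that the 4-ethylbenzyl group, with only two added carbons and no added ring, is enough for a large loss. The number for compound 4 stands within the scatter of that for compound 3, so a substituent need not be as large as phenyl to lose most of what compound 2 gained. No measurement available here explains this loss.

The compounds shown leave open whether a methyl group or a fluorine atom at this aromatic carbon would keep the low number of compound 2. On these data alone, whether ethyl costs as much on the heptanoic acid-type chain of compound 1 also remains open.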